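The compounds below may be only part of what the source reports. "The series", "measured", "known", "first", "only" and "open" are said of these compounds alone.

Of the compounds shown here, two have so far been tested in a functional assay (Platelet, plasma) for inhibition, with Homo sapiens as the target; on this read-out lower numbers stand for stronger inhibition and higher numbers for weaker inhibition. Compound 1 (`N#Cc1cc2c(nc1N1CCC(C(=O)NS(=O)(=O)Cc3ccccc3)C1)COC2=O`) returned only a limit of the assay, > 300000 nM, and not a number. Going by the values given here, compound 2 (`N#Cc1cc2c(nc1N1CCC(C(=O)NS(=O)(=O)Cc3ccccc3F)CC1)COC2=O`) gives 23700 nM, the only actual number in the set, so its standing rests on this single reading. Compound 3 (`N#Cc1cc2c(nc1N1CCC(C(=O)NS(=O)(=O)c3ccc(Cl)s3)CC1)COC2=O`) keeps the core of compound 2 and alters one group: 5-chlorothiophen-2-yl in place of 2-fluorobenzyl on a sulfonyl sulfur. Here, 5-chlorothiophen-2-yl stands in place of 2-fluorobenzyl on a sulfonyl sulfur. Among the compounds with values here, no measured pair shows this kind of change, so any forecast for this assay remains loose. A modest move toward stronger inhibition is expected, although a move the other way cannot be ruled out. The estimated change is a 1.6-fold lower number from compound 2 to compound 3 (0.20 log units; within the scatter). Compound 3 is expected to read 15000 nM, with an estimated range of 3000 nM to 80000 nM.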

Compound 3, half-maximal inhibitory concentration: 4470 nM
Compound 3: middle estimate off by 3.4-fold (0.53 log units), on the high side, and the stated range covers the measured number.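

Going by these compounds alone, on a sulfonyl sulfur whose other neighbours are an amide-type nitrogen, 5-chlorothiophen-2-yl in place of 2-fluorobenzyl gives a 5.3-fold lower number from compound 2 to compound 3 (0.72 log units; beyond the scatter) in this assay and this is the first step in the set that can be read. It shows that the read-out answers to the group at this place while the rest of the molecule stays the same, which compound 2 alone could not show. Ring size, hetero atom and halogen all change at once, however, and this single step cannot separate them.

As far as these compounds go, how a plain thiophen-2-yl, a 5-methylthiophen-2-yl or a phenyl would read on this sulfur remains open. Compound 1 gives only a limit and differs from the others in more than one place, which leaves it outside any comparison: the limit of > 300000 nM in this assay, at which 1 of the 3 values shown sits.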